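Swapping chloro for bromo on compound 3

The compounds below may be only part of what the source reports. "The series", "measured", "known", "first", "only" and "open" are said of these compounds alone.

Compound 1 `N#Cc1cccc(NC(=O)c2cc(F)ccc2O)c1`: "not determined" (no result reported)
Compound 2 `O=C(Nc1ccc(C(F)(F)F)cc1)c1cc(Br)c(F)cc1O`: 1300 nM
Compound 3 `O=C(Nc1ccc(C(F)(F)F)cc1)c1ccc(Cl)cc1O`: 1180 nM

In a functional assay on NALM-6 cells (Homo sapiens) for cytotoxicity, read by luminescence and CellTiter-Glo, with a stated time of 3 days (a higher number here means a weaker inhibitor, a lower number a stronger inhibitor), compound 3 gives 1180 nM, and compound 2 gives 1300 nM; these two values lie within the scatter of each other, and compound 1 offers no number for comparison. Compound 4 `O=C(Nc1ccc(C(F)(F)F)cc1)c1ccc(Br)cc1O` is still unmeasured. It has bromo in place of chloro on an aromatic carbon, meta to a hydroxy group and para to a large group. Within the data shown here, no measured pair isolates this swap. Among the measured compounds shown here, the only guide is compound 2, which also holds a bromo and gives 1300 nM. The expected 1.2-fold lower number from compound 3 to compound 4 (0.07 log units; within the scatter) stays within the scatter in this assay. For compound 4 the estimated value is 1000 nM, with an expected range of 450 nM to 2200 nM.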

Compound 4, half-maximal inhibitory concentration: 690 nM
Estimate against measurement, compound 4: 1.4-fold (0.16 log units) above, within the range that was stated.
By their numbers in this assay, from the lowest: compounds 4, 3 and 2 (each within the scatter of the next).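

Among these compounds, the swap of chloro for bromo on this aromatic carbon, meta to a hydroxy group and para to a large group, is now isolated for the first time: in this assay it gives a 1.7-fold lower number from compound 3 to compound 4 (0.23 log units; within the scatter). At this position, the two halogens therefore cannot be told apart in this assay. No measurement here offers an explanation for the step. The compounds shown leave open whether an amine or a methoxy group on this same carbon would shift the number beyond the scatter.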